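The source may hold more compounds than are shown below. What is called first, only, known or untested is meant among the compounds shown, and "the series" means these compounds.

Notes on the acyl variation in this series. Among the compounds with values here, compound 3 `O=C(C1CCCC1)N1CCN(c2nc(=O)c3cc(C(F)(F)F)cc([N+](=O)[O-])c3s2)CC1` is the only member with a number in an ADME assay on Vero cells (Chlorocebus sabaeus) for cytotoxicity, read by MTT assay, with a stated time of 72 h; a higher number here means that more compound is tolerated, a lower number that less compound is tolerated: compound 3 gives 120000 nM. Compound 1 `O=C(CC1CCCCC1)N1CCN(c2nc(=O)c3cc(C(F)(F)F)cc([N+](=O)[O-])c3s2)CC1` returns a limit rather than a number, compound 1 giving > 125000 nM. Compound 2 `CSCC(=O)N1CCN(c2nc(=O)c3cc(C(F)(F)F)cc([N+](=O)[O-])c3s2)CC1` likewise returns a limit, compound 2 giving > 125000 nM. Both of these sit at the limit of > 125000 nM in this assay, at which 2 of the 3 values shown sit. Between the two limit compounds the step is a step that the two limits leave unreadable from compound 1 to compound 2.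

Compound 4 `CCC(=O)N1CCN(c2nc(=O)c3cc(C(F)(F)F)cc([N+](=O)[O-])c3s2)CC1` differs from compound 3 by ethyl in place of cyclopentyl on a carbonyl carbon. The measured steps that bear on this change both end at compound 3 and alter the same acyl group on the amide-type nitrogen in a ring: an at least 1.0-fold lower number from compound 1 to compound 3 (0.01 log units; that floor lies within the scatter) and an at least 1.0-fold lower number from compound 2 to compound 3 (0.01 log units; that floor lies within the scatter). Within the data shown here, neither separates its two compounds beyond the scatter, and the pattern across all three is flat at or near the top of the range, with no compound among compounds 1, 2 and 3 departing from it. Compound 4 is therefore expected to stay in the same region, with a 1.0-fold higher number from compound 3 to compound 4 (0.02 log units; within the scatter) expected to remain within the scatter and with a real chance that this assay once more reports only a limit. Compound 4 is estimated at 125000 nM, within a range from 70000 nM to 220000 nM.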

Compound 4, half-maximal cytotoxic concentration: > 125000 nM
Compound 4 was reported as a limit; the forecaster's own chance of this, stated with the estimate: 60%; the middle value lies on the limit itself.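

In this assay compound 4 is reported as a limit and not as a number, which places it with compounds 1 and 2: the limit of > 125000 nM in this assay, at which 3 of the 4 values shown sit. Ethyl in place of cyclopentyl on a carbonyl carbon gives an at least 1.0-fold higher number from compound 3 to compound 4 (0.01 log units; that floor lies within the scatter), so at this position the removal of the five-membered ring of carbon only produces no step that can be read beyond the scatter, although that floor is all the limit allows to be read. Within the data shown here, the steps to compound 4 from compounds 1 and 2 cannot be read, but the flat picture now extends to a short open-chain ethyl group, alongside the cyclohexylmethyl of compound 1 and the (methylsulfanyl)methyl of compound 2, and no compound among the four goes against it.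

The compounds shown leave open how far compounds 1, 2 and 4 lie beyond the limit, and therefore whether their acyl groups differ at all in this assay. They also leave open whether an amine, a carboxylic acid or a phenyl ring on the carbonyl carbon would stay in this same region.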